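The source may report more compounds than this note shows. Statements on the series, on what has been measured and on what is new or still open speak of the compounds shown alone.

Measured compounds, with their values in a functional assay on CRL2813 cells (Homo sapiens) for cytotoxicity, read by sulforhodamine B assay, with a stated time of 5 days; on this read-out lower numbers stand for stronger inhibition and higher numbers for weaker inhibition:

compound 1, `CSc1ccccc1NC(=O)N[C@H]1CC[C@H](Oc2ccc(F)cc2)CC1`, gives > 20000 nM, which is a limit of the assay and not a number.
compound 2, `COC(=O)c1cccc(NC(=O)N[C@H]2CC[C@H](Oc3ccc(F)cc3)CC2)c1`, gives 9200 nM.
compound 3, `O=C(Nc1cccc(C(F)(F)F)c1)N[C@H]1CCC[C@H](Oc2ccc(C(F)(F)F)cc2)C1`, gives 3800 nM.

Compound 1 stands only at the limit of this assay; the limit is the one described in the limit of > 20000 nM in this assay, at which 1 of the 3 values shown sits. Compound 2 and compound 3 both give numbers, and the gap between them is within the usual scatter, so no order between them is claimed. Going by the values given here, no step between two measured compounds differing in one place is available, so nothing measured tells how a change on the aryl urea ring moves the value.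

Compound 4, `COc1ccccc1NC(=O)N[C@H]1CC[C@H](Oc2ccc(F)cc2)CC1`, differs from compound 1 by methoxy in place of methylsulfanyl on an aromatic carbon, the group sitting on an aromatic carbon of a six-membered aromatic ring of carbon only, ortho to a large group. In this assay the step from the limit of compound 1 is expected to be small, none beyond the scatter, and the estimate for compound 4 is 20000 nM, with a range from 6000 nM to 60000 nM, the expected step being a number no higher from compound 1 to compound 4 (the limit leaves the size open). A result reported only as a limit is expected to be likely for compound 4.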

Compound 4, half-maximal inhibitory concentration: > 20000 nM
Compound 4: no number, only a limit; the forecaster's own chance of this, stated with the estimate: 55%; the middle value lies on the limit itself.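

Compound 1 and compound 4 are each reported in this assay only as a limit of the assay and not as a number, so no step can be read between them: the limit of > 20000 nM in this assay, at which 2 of the 4 values shown sit.

The compounds shown leave open how far, if at all, going from 2-(methylsulfanyl)phenyl to 2-methoxyphenyl moves the value.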